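The source may hold more compounds than are shown below. What is called first, only, known or untested is meant among the compounds shown, and "the series" means these compounds.

Compound 1 `FC(F)(F)c1ccc(Nc2ncnc3sc(Nc4c(Cl)cccc4Cl)nc23)cc1` is the reference point of this pair. In a functional assay on HEK293 cells for antagonist activity at transient receptor potential cation channel subfamily V member 1 (Rattus norvegicus), read by calcium flux (on this read-out higher numbers stand for weaker inhibition and lower numbers for stronger inhibition), compound 1 gives 3 nM, the lower of the two numbers recorded so far. Among the measured compounds shown here, its only measured neighbour is compound 2 `NS(=O)(=O)c1ccc(Nc2ncnc3sc(Nc4c(Cl)cccc4Cl)nc23)cc1`, which in this assay gives 590 nM; the step of a 200-fold higher number from compound 1 to compound 2 (2.29 log units; beyond the scatter) was a large one and replaced the trifluoromethyl group on the aniline ring with a sulfamoyl group.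

Compound 3 `CC(C)N1CCN(c2nc(Nc3ccc(C(F)(F)F)cc3)c3nc(Nc4c(Cl)cccc4Cl)sc3n2)CC1` has not yet been tested. Relative to compound 1 the change is 4-isopropylpiperazin-1-yl in place of hydrogen on an aromatic carbon. For the measured compounds named here, no measured step touches this part of the shared core: the single step recorded, from compound 1 to compound 2, concerns a substituent on the aniline ring and says nothing about an addition at this carbon of the core. Going by the values given here, on this basis the expected step is a 2.7-fold higher number from compound 1 to compound 3 (0.43 log units; beyond the scatter), a small to moderate loss rather than a gain, resting on no direct precedent. For compound 3 the estimated value in this assay is 8 nM, expected to fall within 2 nM to 40 nM, pending the measurement.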

Compound 3, half-maximal inhibitory concentration: 119 nM
Estimate against measurement, compound 3: 15-fold (1.17 log units) below; measured number above the stated range.
By their numbers in this assay, from the lowest: compound 1; then compound 3; then compound 2.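

The carbon between two ring nitrogen atoms, which carries hydrogen in compound 1, now has its first measured step: in this assay the entry of 4-isopropylpiperazin-1-yl gives a 40-fold higher number from compound 1 to compound 3 (1.60 log units; beyond the scatter) and so shows that this carbon is not indifferent to substitution. The loss is large but inhibition is not abolished, as compound 3 gives 119 nM in this read-out, and the aniline ring, where the sulfamoyl change gave a 200-fold higher number from compound 1 to compound 2 (2.29 log units; beyond the scatter) on the same reference compound, is thus not the only place on the shared core where one change moves the number by a large step. No independent measurement on these compounds bears on the reason for this loss.

With a single group at this carbon, the compounds shown do not separate the contribution of the piperazine ring from that of its isopropyl group. From the compounds shown here alone, a methyl group, a dimethylamino group, a morpholine ring or an unsubstituted piperazine at the same carbon would address that question, and it also remains open whether the addition would behave alike with sulfamoyl in place of trifluoromethyl.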